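This account rests on a few compounds, and the source may have more. Where it says the series, first, only, none or still open, it means among the compounds named here.

Working notes on the series. Compound 1 `c1ccc2c(c1)CN[C@@H](CN(CC1CCNCC1)[C@H]1CCCc3cccnc31)C2`, compound 2 `c1cnc(CN(CCCN2CCNCC2)[C@H]2CCCc3cccnc32)nc1` and compound 3 `c1ccc2c(c1)CN[C@H](CN(CCCN1CCNCC1)[C@H]1CCCc3cccnc31)C2` share one core and differ in the group sitting on a saturated chain carbon bound to an amine nitrogen. In a functional assay on CCRF-CEM cells for antagonist activity at C-X-C chemokine receptor type 4 (Homo sapiens), read by calcium flux, with stated times of 25 min and 90 s (on this read-out higher numbers stand for weaker inhibition and lower numbers for stronger inhibition), compound 1 gives 65 nM, compound 2 gives 4320 nM and compound 3 gives 1150 nM. Compound 3 therefore stands second highest of the three numbers, with compound 2 nearest to it and compound 1 furthest from it. Among the compounds with values here, the single one-point step recorded so far is a 3.8-fold lower number from compound 2 to compound 3 (0.57 log units; beyond the scatter), which exchanges pyrimidin-2-yl for 1,2,3,4-tetrahydroisoquinolin-3-yl and is modest in size.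

Compound 4 `c1cnc2c(c1)CN[C@H](CN(CCCN1CCNCC1)[C@H]1CCCc3cccnc31)C2` has not yet been measured. It differs from compound 3 by a group of 10 heavy atoms (8 carbon, 2 nitrogen; one six-membered non-aromatic ring with 1 hetero atom, one six-membered aromatic ring with 1 hetero atom) in place of a group of 10 heavy atoms (9 carbon, 1 nitrogen; one six-membered non-aromatic ring with 1 hetero atom, one six-membered aromatic ring of carbon only), on a saturated chain carbon bound to an amine nitrogen. Within the data shown here, no measured step turns a six-membered aromatic ring of carbon only into a six-membered aromatic ring with one hetero atom while keeping the rest of the group, so the step from compound 2 to compound 3 bears on this only loosely, showing that the group on that chain carbon can be varied with a modest shift. The exchange here is smaller and is expected to fall within the scatter in this assay, a step of a 1.0-fold higher number from compound 3 to compound 4 (0.02 log units; within the scatter). Compound 4 is estimated at 1200 nM, with a range from 500 nM to 3000 nM.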

Compound 4, half-maximal inhibitory concentration: 2640 nM
Compound 4: middle estimate off by 2.2-fold (0.34 log units), on the low side; measured number inside the range.
By their numbers in this assay, from the lowest: compound 1; then compound 3; then compounds 4 and 2 (each within the scatter of the next).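

In this assay, within the data shown here, the step of a 2.3-fold higher number from compound 3 to compound 4 (0.36 log units; beyond the scatter) is the first to change only the aromatic ring of the group, from a six-membered aromatic ring of carbon only to one with a hetero atom, and it shows that this position responds to that small exchange, modestly but beyond the scatter. The step of a 1.6-fold lower number from compound 2 to compound 4 (0.21 log units; within the scatter) lies within the scatter, so the separation from the pyrimidin-2-yl group seen in the step of a 3.8-fold lower number from compound 2 to compound 3 (0.57 log units; beyond the scatter) with 1,2,3,4-tetrahydroisoquinolin-3-yl does not appear with the group that enters in compound 4, even though that group keeps the non-aromatic ring. No measurement is at hand that would explain the shift from compound 3 to compound 4.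

The compounds shown leave open whether a fluoro or methoxy substituent on the carbon-only aromatic ring would move the number in the same direction as the added ring nitrogen. They also leave open whether the same exchange would give a step of similar size on the core of compound 1, which has the lowest number here.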